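Methyl to Hydrogen on the Shared Core, Cytotoxicity Outlook

The source may hold more compounds than are shown below. What is called first, only, known or untested is meant among the compounds shown, and "the series" means these compounds.

Measured so far:
Compound 1 `COC(=O)c1c[nH]c2cc(OCCOc3ccccc3)ccc2c1=O` — > 20000 nM
Compound 2 `COC(=O)c1c[nH]c2cc(OCCOc3ccccc3)c(C)cc2c1=O` — > 20000 nM
Compound 3 `CCCCc1cc2c(=O)c(I)c(C)[nH]c2cc1OCCOc1ccccc1` — "not determined" (no result reported)

In an ADME assay on J774 cells (Mus musculus) for cytotoxicity (a higher number here means that more compound is needed for the effect, a lower number that less compound is needed), compound 1 gives > 20000 nM, a limit of the assay. Compound 2 gives > 20000 nM in this assay, also a limit. For compound 3 this assay reports "not determined" (no result reported). The step that the two limits leave unreadable from compound 2 to compound 1 is the change (hydrogen in place of methyl on an aromatic carbon); its size is unreadable because both ends sit at the limit of > 20000 nM in this assay, at which 2 of the 3 values shown sit.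

Compound 4 `CCCCc1cc2c(=O)c(I)c[nH]c2cc1OCCOc1ccccc1` is reached from compound 3 by the same kind of change, (hydrogen in place of methyl on an aromatic carbon), but here the place is on a six-membered aromatic ring with one nitrogen, next to the ring nitrogen and ortho to an iodo group, rather than on a ring of carbon only, ortho to a large group. The difference between the cores of compound 3 and compound 2 is not broken down here.

Compound 4 is expected to give about 20000 nM in this assay. Its value is estimated to fall between 5000 nM and 60000 nM. This expectation rests on compound 1 and compound 2 both sitting at the limit of > 20000 nM in this assay, at which 2 of the 3 values shown sit, with no reading for compound 3 to anchor it.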

Compound 4, half-maximal effective concentration: > 10000 nM
Compound 4 gave a limit, no number (the forecaster's own chance of this, stated with the estimate: 60%); the middle value does not contradict the limit.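

In this assay compound 4 gives > 10000 nM, which is a limit. Compound 3 reads "not determined" (no result reported), so no step can be read between compound 3 and compound 4. The compounds shown leave open what hydrogen in place of methyl does to cytotoxicity on either core.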